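Benzyl-substituted nucleosides against G-361 cells: a difluoromethoxy step

A few compounds are considered here, and "the series" means these few. Any claim that something is new, unique, unknown or untested is made for them only; others in the source may bear on it.

Values in a functional assay on G-361 cells (Homo sapiens) for antiproliferative activity, with a stated time of 72 h; a higher number here means a weaker inhibitor, a lower number a stronger inhibitor:
Compound 1 `OC[C@H]1O[C@@H](n2cnc3c(NCc4ccc(Cl)cc4Cl)ncnc32)[C@H](O)[C@@H]1O` gives 128000 nM.
Compound 2 `OC[C@H]1O[C@@H](n2cnc3c(NCc4cc(F)cc(F)c4)ncnc32)C(O)C1O` gives only a limit of the assay, > 166000 nM.
Compound 3 `COc1cc(O)cc(OC)c1CNc1ncnc2c1ncn2[C@@H]1O[C@H](CO)[C@@H](O)[C@H]1O` gives only a limit of the assay, > 166000 nM.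

Within the data shown here, compound 1 holds the only numerical value shown; the other two entries are limits, as the limit of > 166000 nM in this assay, at which 2 of the 3 values shown sit, records. Among the measured compounds shown here, no pair of measured compounds differs in one place, so no measured step exists. Compound 4 `OC[C@H]1O[C@@H](n2cnc3c(NCc4ccccc4OC(F)F)ncnc32)[C@H](O)[C@@H]1O` arises from compound 1 by the change (2-(difluoromethoxy)phenyl in place of 2,4-dichlorophenyl on a saturated chain carbon bound to a nitrogen on an aromatic ring). With most of the series sitting at the limit, compound 4 is expected to stay weak, and the step of a 1.2-fold higher number from compound 1 to compound 4 (0.07 log units; within the scatter) is estimated to lie within the scatter or a little toward weaker inhibition. For compound 4 the estimate in this assay is 150000 nM, with a range of 60000 nM to 400000 nM.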

Compound 4, half-maximal inhibitory concentration: > 166000 nM
Compound 4 was reported as a limit; the forecaster's own chance of this, stated with the estimate: 50%; at least 1.1-fold (0.04 log units) between middle value and limit.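

The change to 2-(difluoromethoxy)phenyl on a saturated chain carbon bound to a nitrogen on an aromatic ring gives the first step measured at this position: an at least 1.2-fold higher number from compound 1 to compound 4 (0.11 log units; that floor lies within the scatter). That step rests on a limit, so it sets only a floor, and the change gives no lower number than compound 1 in this assay. Compound 4 joins the other compounds reported as limits: the limit of > 166000 nM in this assay, at which 3 of the 4 values shown sit.

From the compounds shown here alone, how far the true value of compound 4 lies past its limit stays unknown. Going by these compounds, whether an amine, a carboxylic acid or a longer chain in place of 2,4-dichlorophenyl would give a lower number also remains open.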